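Ortho-fluoro on the benzyl of the shared core

A few compounds are considered here, and "the series" means these few. Any claim that something is new, unique, unknown or untested is made for them only; others in the source may bear on it.

Measured compounds in an assay on isolated protein for inhibition of lactase/phlorizin hydrolase (Rattus norvegicus), read by colorimetric assay; on this read-out higher numbers stand for weaker inhibition and lower numbers for stronger inhibition:
- Compound 1 `Cc1ccc(S(=O)(=O)Nc2ccc3c(c2)C(=O)N(Cc2ccc(Cl)cc2)C3=O)cc1`: 155000 nM
- Compound 2 `Cc1ccc(S(=O)(=O)Nc2ccc3c(c2)C(=O)N(Cc2ccccc2)C3=O)cc1`: > 200000 nM

Compound 2 stands at the weak end of the numbers shown. For compound 2 this assay reports only a limit, > 200000 nM; one of the two values shown sits at this limit (the limit of > 200000 nM in this assay, at which 1 of the 2 values shown sits). Compound 1 gives 155000 nM in this assay. The step of an at least 1.2-fold higher number from compound 1 to compound 2 (0.11 log units; that floor lies within the scatter) is hydrogen in place of chloro on an aromatic carbon.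

Compound 3 `Cc1ccc(S(=O)(=O)Nc2ccc3c(c2)C(=O)N(Cc2ccccc2F)C3=O)cc1` is not yet measured. Its difference from compound 2 is fluoro in place of hydrogen on an aromatic carbon, in words: fluoro in place of hydrogen on an aromatic carbon, ortho to a large group; benzyl becomes 2-fluorobenzyl. Within the data shown here, the only measured step bearing on this position, an at least 1.2-fold higher number from compound 1 to compound 2 (0.11 log units; that floor lies within the scatter), was too small to separate from the scatter, so no shift beyond the scatter is expected in this assay. The expected step is a step that the limit leaves unreadable from compound 2 to compound 3. Compound 3 is therefore estimated at 250000 nM, with a range from 100000 nM to 600000 nM, and a further limit read-out is considered likely.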

Compound 3, half-maximal inhibitory concentration: 180000 nM
For compound 3 the middle estimate is 1.4-fold (0.14 log units) above the measured one; measured number inside the range.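

In this assay, the 2-fluorophenyl of compound 3 and the 4-chlorophenyl of compound 1 give numbers that cannot be told apart, with a 1.2-fold higher number from compound 1 to compound 3 (0.06 log units; within the scatter), so this position now has two halogen-bearing benzyl groups with readable values and no separation between them. Fluoro in place of hydrogen gives an at least 1.1-fold lower number from compound 2 to compound 3 (0.04 log units; that floor lies within the scatter), a floor that does not establish any gain from the 2-fluorobenzyl over the plain benzyl. Compound 2 remains a limit, so the true size of that step stays unknown: the limit of > 200000 nM in this assay, at which 1 of the 3 values shown sits.

The compounds shown leave open whether a benzyl carrying a methoxy, a trifluoromethyl or a carboxylic acid, or a longer chain in place of the benzyl, would move the number in this assay beyond the scatter. Also open, on these data alone, is whether changes elsewhere on the shared core, such as an amine in place of its methyl group, would shift the number more than the halogen changes on the benzyl have so far.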